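Replacing the Benzyl Arm with a Halogenated Phenyl Ring

The source may hold more compounds than are shown below. What is called first, only, known or untested is meant among the compounds shown, and "the series" means these compounds.

Three measured compounds share one core and differ only in the group carried on an amine nitrogen in a ring. Compound 1 `CCCn1c(=O)[nH]c2nc(-c3ccc(S(=O)(=O)N4CCN(Cc5cccc(C)c5)CC4)cc3)[nH]c2c1=O` gives 0.397 nM in an assay on CHO cells for displacement of a labelled ligand from adenosine receptor A2b (Homo sapiens), read by scintillation counting, with a stated time of 75 min, in the presence of a further agent that is not named here; a lower number here means a stronger inhibitor, a higher number a weaker inhibitor. Compound 2 `CCCn1c(=O)[nH]c2nc(-c3ccc(S(=O)(=O)N4CCN(c5ccccc5Br)CC4)cc3)[nH]c2c1=O` gives 0.137 nM, and compound 3 `CCCn1c(=O)[nH]c2nc(-c3ccc(S(=O)(=O)N4CCN(c5ccccc5)C(C)C4)cc3)[nH]c2c1=O` gives 7.15 nM. Among these, compound 1 stands second highest: compound 2 lies nearest with a lower number, while compound 3 lies furthest with a clearly higher one.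

Compound 4 `CCCn1c(=O)[nH]c2nc(-c3ccc(S(=O)(=O)N4CCN(c5ccc(I)cc5)CC4)cc3)[nH]c2c1=O` has not been measured. Relative to compound 1, the change is 4-iodophenyl in place of 3-methylbenzyl on an amine nitrogen in a ring.

Among the measured compounds shown here, the single measured step that bears on this is a 2.9-fold lower number from compound 1 to compound 2 (0.46 log units; beyond the scatter), in which a halogen-bearing phenyl ring took the place of the same 3-methylbenzyl on the same nitrogen. Compound 3 differs from compound 1 in two places at once, so its value shows only that a phenyl on that nitrogen, combined with a methyl on the ring, gives a much higher number than either compound 1 or compound 2. That single step was modest but beyond the scatter, so a comparable decrease is expected for compound 4, namely a 2.0-fold lower number from compound 1 to compound 4 (0.30 log units; within the scatter). Compound 4 is therefore estimated at 0.2 nM, within a range from 0.06 nM to 0.8 nM.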

Compound 4, inhibition constant: 0.159 nM
Estimate against measurement, compound 4: 1.3-fold (0.10 log units) above, within the range that was stated.
By their numbers in this assay, from the lowest: compounds 2 and 4 (each within the scatter of the next); then compound 1; then compound 3.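

The change to 4-iodophenyl in this assay gives a 2.5-fold lower number from compound 1 to compound 4 (0.40 log units; beyond the scatter), so the lower number seen earlier with 2-bromophenyl is not confined to that one group: both halogen-bearing phenyl rings on this amine nitrogen go the same way against 3-methylbenzyl. The new comparison between the two halogenated rings adds something further, since a 1.2-fold higher number from compound 2 to compound 4 (0.06 log units; within the scatter) shows that exchanging bromine for iodine, with its place on the phenyl ring changing at the same time, leaves the number within the scatter. No measurement is available here that would explain these numbers.

Because the halogen and its place on the ring change together between these two compounds, their separate contributions remain unresolved, and neither 2-iodophenyl nor 4-bromophenyl appears among the compounds shown to separate them. On these data alone, it also remains open how a plain phenyl ring on the same nitrogen would read without the methyl carried by compound 3, and whether a phenyl ring bearing a methoxy group, an amine or a carboxylic acid would give a similar number.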